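Amide substituent and cytotoxicity in the shared core

A few compounds are considered here, and "the series" means these few. Any claim that something is new, unique, unknown or untested is made for them only; others in the source may bear on it.

Compound 2 `CC(C)n1ncc2c(C(=O)Nc3cccc(F)c3)cc(-c3cccs3)nc21` carries a 3-fluorophenyl on the amide-type nitrogen. In an ADME assay on LLC-MK2 cells (Macaca mulatta) for cytotoxicity, read by spectrophotometry and crystal violet staining, with a stated time of 4 days (a higher number here means that more compound is tolerated, a lower number that less compound is tolerated), compound 2 gives only a limit, > 200000 nM, not a number. This is the limit of > 200000 nM in this assay, at which 1 of the 3 values shown sits. Compound 1 `CC(C)n1ncc2c(C(=O)Nc3ccncc3)cc(-c3cccs3)nc21` gives 6300 nM in this assay, and compound 3 `CC(C)n1ncc2c(C(=O)N3CCc4cccnc43)cc(-c3cccs3)nc21` gives 50000 nM. The measured steps all sit on the carbonyl side of the shared core: an at least 31-fold higher number from compound 1 to compound 2 (1.50 log units; beyond the scatter), an at least 4.0-fold lower number from compound 2 to compound 3 (0.60 log units; beyond the scatter) and a 7.9-fold higher number from compound 1 to compound 3 (0.90 log units; beyond the scatter). Each of them moved this assay beyond the scatter, and compound 2 holds the highest position among the three.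

Compound 4 `CC(C)n1ncc2c(C(=O)Nc3ccccc3S(N)(=O)=O)cc(-c3cccs3)nc21` differs from compound 2 in the same region: 2-sulfamoylphenyl in place of 3-fluorophenyl on an amide-type nitrogen. No other change of this kind has been measured in the series, so the direction rests on the fact that compound 2 stands at the limit and can only be matched or undercut. Because an at least 31-fold higher number from compound 1 to compound 2 (1.50 log units; beyond the scatter) and an at least 4.0-fold lower number from compound 2 to compound 3 (0.60 log units; beyond the scatter) both lay beyond the scatter, a step beyond the scatter is expected here as well, downward from the limit. Compound 4 is expected to give 50000 nM in this assay, within a range from 12000 nM to 200000 nM. The estimated step is an at least 4.0-fold lower number from compound 2 to compound 4 (0.60 log units; beyond the scatter).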

Compound 4, half-maximal cytotoxic concentration: 25000 nM
The estimate for compound 4 lay 2.0-fold (0.30 log units) above the measured number; measured number inside the range.
By their numbers in this assay, from the lowest: compound 1; then compounds 4 and 3 (each within the scatter of the next). At a limit, above all of these: compound 2.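

In this assay, the change from 3-fluorophenyl to 2-sulfamoylphenyl on the amide-type nitrogen gives an at least 8.0-fold lower number from compound 2 to compound 4 (0.90 log units; beyond the scatter), so a six-membered aromatic ring of carbon only at this place does not by itself secure the position of compound 2. The same 2-sulfamoylphenyl, set against pyridin-4-yl, gives a 4.0-fold higher number from compound 1 to compound 4 (0.60 log units; beyond the scatter), which shows that a carbon-only aromatic ring carrying this larger substituent still stays clear of compound 1, while compound 4 and compound 3 lie within the scatter of each other. For compound 2 the value is a limit and not a number, so the first of these steps has a lower bound only: the limit of > 200000 nM in this assay, at which 1 of the 4 values shown sits.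

The step from compound 2 to compound 4 removes the fluorine and brings in the sulfamoyl group together, so the share of each in the lower number stays unresolved. An unsubstituted phenyl on this nitrogen, or a phenyl carrying a carboxylic acid or an amine, would be needed to separate the two and to show whether the sulfamoyl group is special at this place or only one of many substituents that lower the number.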